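The source may hold more compounds than are shown below. What is called first, only, known or untested is meant among the compounds shown, and "the series" means these compounds.

Going by the values given here, in a functional assay (aorta) with Rattus norvegicus as the target (on this read-out higher numbers stand for weaker inhibition and lower numbers for stronger inhibition), compound 1 (`CC(C)c1cn2ccccc2c1S(=O)(=O)c1ccc(OCCCN2CCN(c3ccccc3)CC2)cc1`) gives 205 nM, the second highest of the three numbers measured so far. Compound 4 (`CCN(CC)CCCOc1ccc(S(=O)(=O)c2c(C(C)C)cn3ccccc23)cc1`) has not yet been measured. It departs from compound 1 by one change, diethylamino in place of 4-phenylpiperazin-1-yl on a saturated chain carbon, three bonds along the chain from an oxygen on an aromatic ring. Among the compounds with values here, the only measured step, a 6.7-fold higher number from compound 2 to compound 3 (0.82 log units; beyond the scatter), lies at a different place in the structure, so it bears on this change only indirectly, as a sign of how far one substitution can move the number. Neither compound 2 (`CC(C)(C)NCCCOc1ccc(S(=O)(=O)c2c(C3CC3)cn3ccccc23)cc1`) at 66.5 nM nor compound 3 (`CC(C)(C)NCCCOc1ccc(S(=O)(=O)c2c(C(C)(C)C)cn3ccccc23)cc1`) at 443 nM carries the 4-phenylpiperazin-1-yl group, and their values fall on either side of that of compound 1, so the data give no firm direction. The expected result is therefore no step beyond the scatter, a 1.4-fold lower number from compound 1 to compound 4 (0.14 log units; within the scatter). Compound 4 is estimated at 150 nM, with an expected range of 40 nM to 550 nM.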

Compound 4, half-maximal inhibitory concentration: 228 nM
Compound 4: middle estimate off by 1.5-fold (0.18 log units), on the low side; low and high end bracket the measured number.
By their numbers in this assay, from the lowest: compound 2; then compounds 1, 4 and 3 (each within the scatter of the next, the first and the last beyond it).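

In this assay, going by these compounds alone, the step of a 1.1-fold higher number from compound 1 to compound 4 (0.05 log units; within the scatter) gives the first reading at this place on the saturated chain, which neither compound 2 nor compound 3 could provide, as the only earlier step lay elsewhere in the structure. The group that leaves holds two rings and 12 heavy atoms, while the group that enters has no ring and 5 heavy atoms, yet the two numbers stay within the scatter of each other, so on this core the read-out does not depend on keeping the 4-phenylpiperazin-1-yl group. No supporting evidence is available to explain this result. On these data alone, whether other amines, such as dimethylamino or morpholine, or a longer chain at this place would give a similar number remains open. Also open, as far as these compounds go, is whether diethylamino would behave the same way with cyclopropyl or tert-butyl on the core.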